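The source may hold more compounds than are shown below. What is called first, only, known or untested is meant among the compounds shown, and "the series" means these compounds.

Compound 1 `O=C(CN1CCCC1)OC1CC2(N3CCCCC3)CC(c3ccccc3)C1C(c1ccccc1)C2` gives 16400 nM in an ADME assay on L6 cells (Rattus norvegicus) for cytotoxicity, read by resazurin assay, with a stated time of 72 h; a higher number here means a weaker inhibitor, a lower number a stronger inhibitor. Compound 2 `CCN(CC)CC(=O)OC1CC2(N3CCCCC3)CC(c3ccccc3)C1C(c1ccccc1)C2` gives 23900 nM. Compound 3 `CCN(CC)CC(=O)OC1CC2(N3CCCC3)CC(c3ccccc3)C1C(c1ccccc1)C2` gives 49000 nM.

Among these three, compound 2 stands second highest: the nearest is compound 1, with a 1.5-fold higher number from compound 1 to compound 2 (0.16 log units; within the scatter), and the furthest is compound 3, with a 2.1-fold higher number from compound 2 to compound 3 (0.31 log units; beyond the scatter). Compound 4 `CN1CCN(CCC(=O)NC2CC3(N4CCCCC4)CC(c4ccccc4)C2C(c2ccccc2)C3)CC1` carries the change (((2-(4-methylpiperazin-1-yl)ethyl)carbonyl)amino in place of (((diethylamino)methyl)carbonyl)oxy on a saturated ring carbon). The two measured steps both vary only the amine portion, and both were small, one within the scatter and one modest. Within the data shown here, no measured step exchanges the ester linkage for an amide, so the change to compound 4 is only loosely covered. The expectation in this assay is a step no larger than the scatter, in no firm direction, that is a 1.0-fold higher number from compound 2 to compound 4 (0.02 log units; within the scatter). Compound 4 is therefore estimated at 25000 nM, with a range from 9000 nM to 70000 nM.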

Compound 4, half-maximal inhibitory concentration: 61100 nM
Compound 4: the middle estimate sits 2.4-fold (0.39 log units) below what was measured; the measured number falls inside the stated range.
By their numbers in this assay, from the lowest: compounds 1 and 2 (each within the scatter of the next); then compounds 3 and 4 (each within the scatter of the next).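

In this assay, among these compounds, the first change of the linkage at this saturated ring carbon, from carbonyl-oxy to carbonyl-amino, comes with a 2.6-fold higher number from compound 2 to compound 4 (0.41 log units; beyond the scatter) and with a 3.7-fold higher number from compound 1 to compound 4 (0.57 log units; beyond the scatter). Among the compounds shown here, both steps lie beyond the scatter and point towards weaker inhibition, whereas the earlier steps altered only the amines. Nothing at hand accounts for this shift.

On these data alone, the change replaces the linkage, the chain and the amine together, so their separate shares remain open. An amide carrying diethylamino on the original chain, or a morpholin-4-yl group in place of 4-methylpiperazin-1-yl, would begin to separate them.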